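The compounds below may be only part of what the source reports. "The series", "measured", "known", "first", "only" and "open" are said of these compounds alone.

Measured compounds in an ADME assay on NIH3T3 cells (Mus musculus) for cytotoxicity, read by CCK-8 assay, with a stated time of 24 h; a lower number here means a stronger inhibitor, a higher number a weaker inhibitor:

compound 1 `C/C(=C\c1ccc(-c2ccc(C)cc2)o1)C(N)=O` gives > 50000 nM, which is a limit of the assay and not a number.
compound 2 `C/C(=C\c1cc(-c2ccc(F)cc2)cs1)C(N)=O` gives > 50000 nM, again a limit of the assay and not a number.
compound 3 `C/C(=C\c1nc(-c2ccccc2)cs1)C(N)=O` gives > 50000 nM, again a limit of the assay and not a number.

Compound 2 therefore stands where every value shown stands: at the limit, with no number to place it against compound 1 or compound 3. Among the measured compounds shown here, the only evidence on the series is the limit of > 50000 nM in this assay, at which 3 of the 3 values shown sit, so no step between two measured numbers can be drawn from it.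

Compound 4 `C/C(=C\c1cc(-c2ccc(S(C)(=O)=O)cc2)cs1)C(N)=O` has not been measured in this assay. It differs from compound 2 by methylsulfonyl in place of fluoro on an aromatic carbon. With all three values shown resting at the limit, no step beyond the scatter is expected from compound 2 to compound 4 in either direction; the expected step is a step that the limit leaves unreadable from compound 2 to compound 4. Compound 4 is accordingly expected to give 60000 nM, within 30000 nM to 150000 nM, and most likely the assay will again report only a limit.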

Compound 4, half-maximal inhibitory concentration: > 50000 nM
Compound 4 was reported as a limit; the forecaster's own chance of this, stated with the estimate: 85%; the middle value is on the limit's open side.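

Among the compounds shown here, compound 2 and compound 4 both sit at the assay limit, and no step between them can be read for methylsulfonyl in place of fluoro on an aromatic carbon. The compounds shown leave open what structure, if any, would give a measurable number in this assay.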